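The source may hold more compounds than are shown below. What is called first, only, known or untested is meant among the compounds shown, and "the series" means these compounds.

Compound 2 `CCOC(=O)C1CCN(c2ncnc(Nc3ccc(S(C)(=O)=O)cc3)c2[N+](=O)[O-])CC1` gives 1200 nM in a functional assay on HEK293 cells for agonist activity at Glucose-dependent insulinotropic receptor (Homo sapiens), read by cAMP accumulation (on this read-out lower numbers stand for an effect already at smaller amounts and higher numbers for an effect only at larger amounts of compound), and compound 1 `CCOC(=O)C1CCN(c2ncnc(Oc3ccc(C(=O)CC(=O)OC)cc3)c2[N+](=O)[O-])CC1` gives 1000 nM; these two values lie within the usual scatter of each other, so neither counts as stronger. Compound 3 `CCOC(=O)C1CCN(c2ncnc(Nc3ccc(-n4cncn4)cc3)c2[N+](=O)[O-])CC1` carries 1H-1,2,4-triazol-1-yl in place of methylsulfonyl on an aromatic carbon, that is, 1H-1,2,4-triazol-1-yl in place of methylsulfonyl on an aromatic carbon. Among the compounds with values here, no measured pair shows what such a swap does here, so the expected step of a 1.2-fold lower number from compound 2 to compound 3 (0.08 log units; within the scatter) is small, in no firm direction, and not beyond the scatter. For compound 3 the estimate is 1000 nM, with a range from 300 nM to 3500 nM.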

Compound 3, half-maximal effective concentration: 400 nM
Beside the measured number, compound 3's estimate is 2.5-fold (0.40 log units) above it; the measured number falls inside the stated range.
By their numbers in this assay, from the lowest: compound 3; then compounds 1 and 2 (each within the scatter of the next).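

Within the data shown here, this pair is the first to isolate a change at this position, on an aromatic carbon para to a large group: 1H-1,2,4-triazol-1-yl in place of methylsulfonyl gives a 3.0-fold lower number from compound 2 to compound 3 (0.48 log units; beyond the scatter) in this assay. It shows that the group here can shift the read-out beyond the scatter, and that a five-membered aromatic ring fits at this position without loss. Nothing at hand explains the step. Still open, on these data alone, is how an amine, a carboxylic acid or a longer chain at this position would compare, and whether the same swap gives a similar step with other groups elsewhere on the shared core.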